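Replacing an isopropylamino group with a 2-oxopyrrolidinyl ring

The source may report more compounds than this note shows. Statements on the series, on what has been measured and on what is new or still open speak of the compounds shown alone.

Measured compounds:
- Compound 1, `Cc1noc(NS(=O)(=O)c2cccc3c(Cl)cccc23)c1C`: 24000 nM
- Compound 2, `Cc1noc(NS(=O)(=O)c2cccc3c(NC(C)C)cccc23)c1C`: 20 nM

Going by the values given here, in an assay on VSM-A10 cells for antagonist activity at Endothelin-1 receptor (Rattus norvegicus) (a higher number here means a weaker inhibitor, a lower number a stronger inhibitor), compound 2 gives the lowest number of the two measured, and its only neighbour is compound 1, which sits a 1200-fold lower number from compound 1 to compound 2 (3.08 log units; beyond the scatter) away in the opposite direction. That single step, from a chloro substituent to an isopropylamino group, is the whole of the evidence available for this position on the shared core.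

Compound 3, `Cc1noc(NS(=O)(=O)c2cccc3c(N4CCCC4=O)cccc23)c1C`, differs from compound 2 only in that position: 2-oxopyrrolidin-1-yl in place of isopropylamino on an aromatic carbon. Among the compounds with values here, no measured pair shows this exchange, and the step from compound 1 to compound 2 bears on it only by showing that the substituent at this position can move the number a great deal. The isopropylamino group that gave compound 2 its low number leaves, and a group of a different kind enters, so the number is expected to move upward rather than downward, by an uncertain amount.

Compound 3 is therefore expected to give about 150 nM, within 20 nM to 1500 nM, a step of a 7.5-fold higher number from compound 2 to compound 3 (0.88 log units; beyond the scatter) relative to compound 2.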

Compound 3, half-maximal inhibitory concentration: 130 nM
The estimate for compound 3 lay 1.2-fold (0.06 log units) above the measured number; the range from low to high includes it.
By their numbers in this assay, from the lowest: compound 2; then compound 3; then compound 1.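

In this assay, the exchange gives a 6.5-fold higher number from compound 2 to compound 3 (0.81 log units; beyond the scatter) and so gives back only part of what the position gained over chloro, since the larger step of a 180-fold lower number from compound 1 to compound 3 (2.27 log units; beyond the scatter) still stands beyond the scatter. A low number at this position is therefore not tied to isopropylamino alone: 2-oxopyrrolidin-1-yl, which brings a five-membered non-aromatic ring and has 0 hydrogen-bond donors, also stays far below chloro, though compound 2 keeps the lowest number of the three. Nothing given here accounts for either step.

The compounds shown leave open which feature of 2-oxopyrrolidin-1-yl matters, as the ring and the carbonyl enter together; an open-chain acetamido group and a plain pyrrolidin-1-yl ring would each carry only one of them. They also leave open whether the attaching nitrogen, common to compound 2 and compound 3, is needed at all, a question that a cyclopentyl group or an isobutyl chain on the same aromatic carbon would address.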